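The compounds below may be only part of what the source reports. "The series", "measured", "known", "first", "only" and "open" are said of these compounds alone.

Measured in an ADME assay on cells (Peritoneal macrophage cell, Mus musculus) for cytotoxicity, read by fluorescence and resazurin assay, with a stated time of 3 days (on this read-out lower numbers stand for higher toxicity in this test and higher numbers for lower toxicity in this test), each value a limit:
- Compound 1 `O=C(Nc1cc(-c2ccccn2)n[nH]1)N1CCC(c2ccc(F)cc2)CC1`: > 64000 nM
- Compound 2 `O=C(Nc1cc(-c2ccccn2)n[nH]1)N1CCC(c2ccc(Cl)cc2)CC1`: > 55000 nM
- Compound 3 `O=C(Nc1cc(-c2ccccn2)n[nH]1)N1CCC(c2ccccc2)CC1`: > 64000 nM

Compound 3 has only a limit, not a number, at > 64000 nM. The three limits fall into two groups: the limit of > 64000 nM in this assay, at which 2 of the 3 values shown sit, and (the limit of > 55000 nM in this assay, at which 1 of the 3 values shown sits).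

Compound 4 `O=C(Nc1cc(-c2ccccn2)n[nH]1)N1CCC(Oc2ccccn2)CC1` has (pyridin-2-yl)oxy in place of phenyl on a saturated ring carbon. The nearest measured evidence is a step that the two limits leave unreadable from compound 1 to compound 3 and a step that the two limits leave unreadable from compound 2 to compound 3. Neither has a readable size, and both swap a different group, so they offer no sign of a real change. With compound 3 at > 64000 nM, no step beyond the scatter is expected in this assay, and another limit is likely. The expected step is a number no higher from compound 3 to compound 4 (the limit leaves the size open). For compound 4 the estimate is 64000 nM, with an expected range from 30000 nM to 100000 nM.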

Compound 4, half-maximal cytotoxic concentration: > 64000 nM
Compound 4: only a limit was reported; the forecaster's own chance of this, stated with the estimate: 80%; the middle value sits exactly at the limit.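

In this assay compound 4 gives only a limit, > 64000 nM. Going by these compounds alone, compound 1, compound 2 and compound 3 also have only limits, so no step to compound 4 can be read. The compounds shown leave open what concentration, if any, would harm these cells.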